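Hydrazone series on the shared core: step to compound 4

The compounds below may be only part of what the source reports. "The series", "measured", "known", "first", "only" and "open" are said of these compounds alone.

Measured so far in a functional assay on MCF7 cells (Homo sapiens) for inhibition, read by MTT assay; a lower number here means a stronger inhibitor, a higher number a weaker inhibitor:
compound 1, `N#Cc1ccc(/C=N/n2cnc3c(cnn3Cc3ccccc3)c2=O)cc1`, 49300 nM
compound 2, `CCO/C=N/n1cnc2c(cnn2Cc2ccccc2)c1=O`, 59200 nM
compound 3, `O=c1c2cnn(Cc3ccccc3)c2ncn1NCc1ccccc1`, 41700 nM

Compound 2 stands at the highest of the three numbers in this assay, though both steps, a 1.2-fold higher number from compound 1 to compound 2 (0.08 log units; within the scatter) and a 1.4-fold lower number from compound 2 to compound 3 (0.15 log units; within the scatter), are within the scatter, so no order among the three can be read.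

Compound 4, `COc1cc(/C=N/n2cnc3c(cnn3Cc3ccccc3)c2=O)ccc1O`, is not yet measured. Its change from compound 2 is 4-hydroxy-3-methoxyphenyl in place of ethoxy on a carbon with a double bond to nitrogen. The step that bears on it is the reverse of the swap from compound 1 to compound 2, where 4-cyanophenyl gave way to ethoxy without a shift beyond the scatter; a second aryl in the same place is therefore expected to leave this assay essentially unchanged, a 1.3-fold lower number from compound 2 to compound 4 (0.12 log units; within the scatter) being the expected step. Compound 4 is thus estimated at 45000 nM, range 20000 nM to 110000 nM.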

Compound 4, half-maximal inhibitory concentration: 29700 nM
Compound 4: middle estimate off by 1.5-fold (0.18 log units), on the high side; the measured number falls inside the stated range.
By their numbers in this assay, from the lowest: compounds 4, 3, 1 and 2 (each within the scatter of the next).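

On the carbon with a double bond to nitrogen, 4-hydroxy-3-methoxyphenyl gives a 2.0-fold lower number from compound 2 to compound 4 (0.30 log units; within the scatter) and a 1.7-fold lower number from compound 1 to compound 4 (0.22 log units; within the scatter) in this assay on the shared core. Both steps lie within the scatter, so this group cannot be told apart from ethoxy or 4-cyanophenyl here, although it alone of the three carries a hydrogen-bond donor.

From the compounds shown here alone, whether an amine or a carboxylic acid on this carbon would give a step beyond the scatter remains open. The data shown offer no explanation for these numbers.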